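Second hydroxymethyl on the fused core: expected potency

The source may report more compounds than this note shows. Statements on the series, on what has been measured and on what is new or still open speak of the compounds shown alone.

Of the compounds shown here, two have been tested so far. Compound 1 `Cc1c(CO)cc2n1[C@@H](c1ccccc1)SC2` carries a methyl and a hydroxymethyl on the five-membered aromatic ring of the fused core, and in a functional assay on A-375 cells (Homo sapiens) for cytotoxicity, read by MTT assay, with a stated time of 48 h (a higher number here means a weaker inhibitor, a lower number a stronger inhibitor), compound 1 gives 69800 nM. Compound 2 `Cc1cc(CO)c2n1[C@@H](c1ccccc1)SC2` places the same two groups on other positions of that ring, and in this assay compound 2 gives 106000 nM. Compound 2 stands at one end of the two numbers recorded; its nearest neighbour is compound 1, and the gap between the two lies within the usual scatter, so they cannot be told apart. Both are weak inhibitors of these cells.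

Compound 3 `Cc1c(CO)c(CO)c2n1[C@@H](c1ccccc1)SC2` is the next member to be measured. Relative to compound 2 the change is hydroxymethyl in place of hydrogen on an aromatic carbon. Among the compounds with values here, no measured pair shows the effect of adding a second hydroxymethyl to this ring, and the two values at hand give no trend to build on. The step from compound 2 to compound 3 is therefore expected to be a 1.1-fold lower number from compound 2 to compound 3 (0.03 log units; within the scatter), none beyond the scatter. For compound 3 in this assay the estimate is 100000 nM, with a range from 40000 nM to 250000 nM.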

Compound 3, half-maximal inhibitory concentration: 36100 nM
Beside the measured number, compound 3's estimate is 2.8-fold (0.44 log units) above it, outside the stated range (below it).
By their numbers in this assay, from the lowest: compounds 3, 1 and 2 (each within the scatter of the next, the first and the last beyond it).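

In this assay, within the data shown here, the step of a 2.9-fold lower number from compound 2 to compound 3 (0.47 log units; beyond the scatter) is modest but beyond the scatter, the first such step: hydroxymethyl in place of hydrogen on an aromatic carbon of the five-membered aromatic ring does not weaken compound 2 and gives it a lower number. Read from the other parent, the same replacement gives a 1.9-fold lower number from compound 1 to compound 3 (0.29 log units; within the scatter) and stays within the scatter, so the improvement is seen from only one of the two parents and cannot be claimed as a general effect of a second hydroxymethyl. What the two steps do show is that the shared core carries hydroxymethyl on both ring carbons without loss on these cells, and no supporting data bear on the reason for the step.

Going by these compounds, it remains open whether the step belongs to hydroxymethyl itself or would also appear with a carboxylic acid, an aminomethyl group or a longer chain such as hydroxyethyl on the same carbon. Whether any change on this ring can move the series far from the present high numbers also remains open, since the three compounds shown differ only modestly.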